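Swapping an Ester for a Phenyl Group on a Saturated Ring

A few compounds are considered here, and "the series" means these few. Any claim that something is new, unique, unknown or untested is made for them only; others in the source may bear on it.

Of the compounds shown here, three built on one shared core have been tested in a functional assay on SH-SY5Y cells (Homo sapiens) for antiproliferative activity, read by MTT assay, with a stated time of 72 h; on this read-out higher numbers stand for weaker inhibition and lower numbers for stronger inhibition. Compound 1 `COc1cc2c(Nc3ccc(C#N)cc3)ncnc2cc1OCCCN1CCCCC1` carries an unsubstituted saturated ring at the end of its side chain, and in this assay compound 1 gives 18800 nM. Compound 2 `COc1cc2c(Nc3ccc(C#N)cc3)ncnc2cc1OCCCN1CCC(O)CC1` adds a hydroxy group to a carbon of that ring; for compound 2 this assay returns only a limit, > 100000 nM. Compound 3 `CCOC(=O)C1CCN(CCCOc2cc3ncnc(Nc4ccc(C#N)cc4)c3cc2OC)CC1` instead carries an ethoxycarbonyl group on the saturated ring carbon, and compound 3 gives 47200 nM, the higher of the two plain numbers reported, with compound 1 as its nearest neighbour. The step of a 2.5-fold higher number from compound 1 to compound 3 (0.40 log units; beyond the scatter) shows that the ethoxycarbonyl weakened inhibition, an at least 5.3-fold higher number from compound 1 to compound 2 (0.72 log units; beyond the scatter) shows the hydroxy group weakened it further, and an at least 2.1-fold lower number from compound 2 to compound 3 (0.32 log units; beyond the scatter) separates those two substituents.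

Compound 4 `COc1cc2c(Nc3ccc(C#N)cc3)ncnc2cc1OCCCN1CCC(c2ccccc2)CC1` has not yet been measured. Its change from compound 3 is phenyl in place of ethoxycarbonyl on a saturated ring carbon. Within the data shown here, no measured step involves a phenyl group, so the measured steps only indicate that each substituent tried so far on this ring carbon raised the number relative to hydrogen, by a modest amount in the case of the ethoxycarbonyl. Compound 4 is therefore expected to give about 25000 nM, within a range of 8000 nM to 80000 nM. The expected step of a 1.9-fold lower number from compound 3 to compound 4 (0.28 log units; within the scatter) is estimated to be small, perhaps a slight move toward compound 1.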

Compound 4, half-maximal inhibitory concentration: 7770 nM
For compound 4 the middle estimate is 3.2-fold (0.51 log units) above the measured one; the measured number lies below the stated range.
By their numbers in this assay, from the lowest: compound 4; then compound 1; then compound 3. At a limit, above all of these: compound 2.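

Among these compounds, compound 4 is the first compound here in which a group on this saturated ring carbon lowers the number relative to hydrogen, with a 2.4-fold lower number from compound 1 to compound 4 (0.38 log units; beyond the scatter) in this assay, whereas ethoxycarbonyl and hydroxy both raised it. A substituent at this place therefore need not weaken inhibition, and the choice of group matters: the ethoxycarbonyl that leaves contains oxygen and hydrogen-bond acceptors, the phenyl that enters is carbon only, and the exchange gives a 6.1-fold lower number from compound 3 to compound 4 (0.78 log units; beyond the scatter). The largest change, an at least 12-fold lower number from compound 2 to compound 4 (1.10 log units; beyond the scatter), starts from compound 2, which has only a limit and not a plain number: the limit of > 100000 nM in this assay, at which 1 of the 4 values shown sits.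

On these data alone, these compounds cannot separate the aromatic ring of phenyl from its all-carbon makeup, so it stays open whether a cyclohexyl group at this place would match phenyl or whether a benzyl group, with its ring set one carbon further out, would do better or worse. As far as these compounds go, how an amine or a carboxylic acid on this ring carbon would compare, and whether a chloro or methoxy group on the phenyl ring would shift the number further, also remains unknown.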